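Aryl ether variation in a positive allosteric modulator series

The source may report more compounds than this note shows. Statements on the series, on what has been measured and on what is new or still open speak of the compounds shown alone.

Measured so far:
compound 1 `Cc1ccc(N2CCn3nc(COc4ccccc4)cc3C2=O)nc1`, which in a functional assay on HEK293 cells for positive allosteric modulation of metabotropic glutamate receptor 5 (Homo sapiens), read by calcium flux (a lower number here means a smaller maximal response, a higher number a larger maximal response), gives 76%;
compound 2 `O=C1c2cc(COc3cccc(F)c3)nn2CCN1c1ccc(F)cc1`, which in this assay gives 70%.

Compound 2 holds the lower of the two numbers, but compound 1 sits only a few points higher, and the two values fall within the scatter of each other; no ordering between them can be read from this pair.

The next compound is compound 3 `O=C1c2cc(COc3ccncc3)nn2CCN1c1ccc(F)cc1`. It differs from compound 2 in one place: pyridin-4-yl in place of 3-fluorophenyl on an oxygen on a saturated carbon. Within the data shown here, no step between two measured compounds touches this part of the structure, so there is no measured precedent for the change.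

Given the value of compound 2 in this assay, 70%, the expectation for compound 3 is a step of a number 2 percentage points lower from compound 2 to compound 3 (within the scatter), that is, no change beyond the scatter in either direction. On that basis compound 3 is estimated at 68%, with a range from 45% to 90%.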

Compound 3, largest response reached (Emax), in percent of the reference or control that the assay uses: 69%
Estimate against measurement, compound 3: 1 percentage points below; measured number inside the range.
By their numbers in this assay, from the lowest: compounds 3, 2 and 1 (each within the scatter of the next).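

In this assay, among these compounds, the change from 3-fluorophenyl to pyridin-4-yl is the first measured step at this position, on an oxygen on a saturated carbon, and it reads a number 1 percentage points lower from compound 2 to compound 3 (within the scatter). An aromatic ring of carbon only can therefore give way to one carrying a ring nitrogen, with one hydrogen-bond acceptor gained, and the maximal response stays within the scatter in this pair. Nothing available accounts for this result.

Still open, from the compounds shown here alone, is whether the position keeps this response with a group of another kind on the oxygen, such as a saturated cyclohexyl ring, a longer chain ending in an amine, or a carboxylic acid. Going by these compounds, it is also open whether pyridin-4-yl gives the same outcome when placed on compound 1.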